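This account rests on a few compounds, and the source may have more. Where it says the series, first, only, none or still open, it means among the compounds named here.

Measured so far in a functional assay on V79-379A cells (Cricetulus griseus) for cytotoxicity, read by MTT assay, in the presence of a further agent that is not named here; on this read-out higher numbers stand for weaker inhibition and lower numbers for stronger inhibition:
- compound 1 `COC1=CC(=O)c2c(c(COC(=O)c3ccc(F)cc3)c(C)n2C)C1=O`: 27000 nM
- compound 2 `COC1=CC(=O)c2c(c(COC(C)=O)c(C)n2C)C1=O`: 27000 nM

Compound 2 stands level with compound 1 at the digits shown, so neither can be ranked above the other. The next structure is compound 3 `COC1=CC(=O)c2c(c(Cc3ccc(O)c(F)c3)c(C)n2C)C1=O`, and the change is 3-fluoro-4-hydroxyphenyl in place of acetoxy on a saturated chain carbon bound to an aromatic carbon.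

Within the data shown here, only one measured step bears on this: no change at the digits printed from compound 1 to compound 2 (within the scatter). That step exchanged methyl for 4-fluorophenyl on a carbonyl carbon, whereas here the whole acetoxy leaves. Among the measured compounds shown here, no measured compound shows such a replacement, so the step offers only weak guidance and the direction remains open. The expectation therefore starts from compound 2 at 27000 nM and foresees no shift beyond the scatter in this assay, with wide margins on either side. The expected move is a 1.1-fold lower number from compound 2 to compound 3 (0.03 log units; within the scatter). In this assay the estimate for compound 3 is 25000 nM, with an expected range of 6000 nM to 90000 nM.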

Compound 3, half-maximal inhibitory concentration: 470000 nM
Compound 3: the middle estimate sits 19-fold (1.27 log units) below what was measured, outside the stated range (above it).
By their numbers in this assay, from the lowest: compounds 1 and 2 (each within the scatter of the next); then compound 3.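

At the saturated chain carbon bound to an aromatic carbon, the exchange of acetoxy for 3-fluoro-4-hydroxyphenyl gives a 17-fold higher number from compound 2 to compound 3 (1.24 log units; beyond the scatter) in this assay, whereas the earlier change on the carbonyl carbon gave no change at the digits printed from compound 1 to compound 2 (within the scatter). This position is therefore not indifferent to what it carries: the step runs towards weaker inhibition, and the level shared by the two acyloxy compounds does not hold once the acetoxy leaves and this aromatic ring enters. The compounds shown offer no measurement that accounts for the size of this step.

The step removes the acetoxy and introduces the ring, its fluorine and its hydroxyl all at once, so the contribution of each part to the shift cannot be separated. Still open, going by these compounds, is where a plain phenyl, a 4-hydroxyphenyl or a 3-fluorophenyl on the same carbon would fall relative to compound 2 and compound 3, and whether a small non-aromatic group such as an amine or a methoxy would stay level with compound 2.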